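Compound 3 to compound 4: 2-methylphenyl for 3-hydroxyphenyl

This account rests on a few compounds, and the source may have more. Where it says the series, first, only, none or still open, it means among the compounds named here.

- Compound 1 `CC1(C)[C@H]2CC[C@]1(C)N(Cc1cn(-c3cccc(C#N)c3)nn1)C(=O)C2`: 40 nM
- Compound 2 `CC1(C)[C@H]2CC[C@]1(C)N(Cc1cn(-c3ccccc3Cl)nn1)C(=O)C2`: 60 nM
- Compound 3 `CC1(C)[C@H]2CC[C@]1(C)N(Cc1cn(-c3cccc(O)c3)nn1)C(=O)C2`: 70 nM

These three compounds share one core and differ only in the aromatic group on the ring with 3 nitrogen. All were tested in a functional assay on HepG2 cells (Homo sapiens) for inhibition, read by MTT assay, with a stated time of 24 h; a higher number here means a weaker inhibitor, a lower number a stronger inhibitor. There, compound 3 gives 70 nM, which cannot be told apart from the other two: the data show a 1.2-fold higher number from compound 2 to compound 3 (0.07 log units; within the scatter) and a 1.8-fold higher number from compound 1 to compound 3 (0.24 log units; within the scatter).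

Compound 4 `Cc1ccccc1-n1cc(CN2C(=O)C[C@@H]3CC[C@@]2(C)C3(C)C)nn1` has not yet been measured. It carries 2-methylphenyl in place of 3-hydroxyphenyl on an aromatic nitrogen. Within the data shown here, no measured compound carries this exact group, so the evidence is indirect. The closest measured group by name is the 2-chlorophenyl of compound 2, and the step to compound 3 stayed small, as did the remaining one, a 1.5-fold higher number from compound 1 to compound 2 (0.18 log units; within the scatter). Every change of this aromatic group so far has stayed within the scatter, so no real shift is expected in this assay. The expected change is a 1.2-fold lower number from compound 3 to compound 4 (0.07 log units; within the scatter). For compound 4 the estimated value is 60 nM, with an expected range from 30 nM to 120 nM.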

Compound 4, half-maximal inhibitory concentration: 150 nM
The estimate for compound 4 lay 2.5-fold (0.40 log units) below the measured number; measured number above the stated range.
By their numbers in this assay, from the lowest: compounds 1, 2 and 3 (each within the scatter of the next); then compound 4.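

Among these compounds, until this result, no swap of the aromatic group on the ring nitrogen had moved the number beyond the usual scatter in this assay, but 2-methylphenyl does so against all three earlier groups, with a 2.1-fold higher number from compound 3 to compound 4 (0.33 log units; beyond the scatter) and a 3.8-fold higher number from compound 1 to compound 4 (0.57 log units; beyond the scatter) as its steps from the 3-hydroxyphenyl and 3-cyanophenyl compounds. The closest pair is the most telling: exchanging chloro for methyl on an aromatic carbon, with the rest of the molecule unchanged, gives a 2.5-fold higher number from compound 2 to compound 4 (0.40 log units; beyond the scatter) and shows that this position is not indifferent to even a single-group change, although all three steps remain modest. No measurement shown here explains why the methyl compound gives the higher number.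

The compounds shown leave open whether this rise is specific to methyl or would also appear with a larger carbon group such as ethyl or isopropyl. They also do not show how a methoxy group, an amine or a carboxylic acid on the phenyl ring would read in this assay on this shared core.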